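The source may report more compounds than this note shows. Statements on the series, on what has been measured and on what is new or still open speak of the compounds shown alone.

Measured compounds:
compound 1 `O=C(CSc1nnnn1-c1ccccc1)N/N=c1/scc(-c2ccc(F)cc2)n1-c1ccccc1`, 30.6% in a functional assay on C6 cells (Rattus norvegicus) for cytotoxicity, read by MTT assay, with a stated time of 24 h, tested at 200 ug/mL; on this read-out higher numbers stand for a weaker effect at the one concentration tested and lower numbers for a stronger effect
compound 2 `Cn1cnnc1SCC(=O)N/N=c1/scc(-c2ccccc2)n1-c1ccccc1`, 35.5% in this assay

Both numbers come from this assay at a single concentration. Compound 2 carries the larger of the two figures, but the gap to compound 1 is within the scatter of repeated measurements, so the two read-outs cannot be told apart; neither compound is called stronger or weaker than the other.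

Compound 3 `O=C(CSc1nnnn1-c1ccccc1)N/N=c1/scc(-c2ccccc2)n1-c1ccccc1` is not yet measured in this assay. It is reached from compound 2 by one change: 1-phenyl-1H-tetrazol-5-yl in place of 4-methyl-4H-1,2,4-triazol-3-yl on a sulfur. The group that enters is the one already present on the sulfur of compound 1, which gives 30.6%.

For the measured compounds named here, no step between measured compounds is available to calibrate this change. Given that compound 1 and compound 2 sit within the scatter of each other, no step beyond the scatter is expected in this assay, and the direction is left open. The expected step from compound 2 to compound 3 is a number 3.5 percentage points lower from compound 2 to compound 3 (within the scatter). Compound 3 is estimated at 32%, with a range from 20% to 45%.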

Compound 3, a percentage reported as activity, at one concentration (the size of the read-out at that concentration, not a potency): 22.6%
Compound 3: middle estimate off by 9.4 percentage points, on the high side; measured number inside the range.
By their numbers in this assay, from the lowest: compounds 3, 1 and 2 (each within the scatter of the next, the first and the last beyond it).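

In this assay, for the compounds shown here, 1-phenyl-1H-tetrazol-5-yl in place of 4-methyl-4H-1,2,4-triazol-3-yl on a sulfur gives a number 12.9 percentage points lower from compound 2 to compound 3 (beyond the scatter) and is the only step that clears the scatter, so the group on the sulfur is a place where a change can register on this read-out. Hydrogen in place of fluoro on an aromatic carbon gives a number 8 percentage points lower from compound 1 to compound 3 (within the scatter) and cannot be read as an effect of that change, which leaves the fluoro group without a demonstrated contribution at the one concentration tested. Nothing available bears on why the change on the sulfur shifts the number.

The entering group differs from the leaving one in both its five-membered ring and its added phenyl ring, so the compounds shown cannot say which part carries the step, and a 1-methyl-1H-tetrazol-5-yl group on the sulfur would separate the two. On these data alone, whether the step holds with an amine or a carboxylic acid on that phenyl ring also stays open, as does whether the stronger effect seen at the one concentration tested would carry over to any other concentration.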